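Sigma-2 binding: aryl substituent change in triazole series

The source may report more compounds than this note shows. Statements on the series, on what has been measured and on what is new or still open speak of the compounds shown alone.

The series shares the core carried by compound 1 `Cn1nc(CN2CCCC2)nc1-c1ccc2c(c1)CCCC2` and compound 2 `Cn1nc(CN2CCCC2)nc1-c1cccc(Oc2ccccc2)c1`, which differ only in the aryl group attached to it. In an assay on membranes from Jurkat cells for displacement of a labelled ligand from Sigma intracellular receptor 2 (Homo sapiens), read by scintillation counting, with a stated time of 1 h (a higher number here means a weaker inhibitor, a lower number a stronger inhibitor), compound 1 gives > 1000 nM, a limit of the assay rather than a number. In this assay compound 2 likewise gives > 1000 nM, again a limit and not a number. Going by the values given here, both values sit at the limit of > 1000 nM in this assay, at which 2 of the 2 values shown sit, so no step between measured compounds can be drawn, and compound 2 cannot be placed relative to compound 1 beyond the fact that neither reaches a measurable value.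

Compound 3 `Cn1nc(CN2CCCC2)nc1-c1cccc(C(C)(C)C)c1` has not yet been measured. It differs from compound 2 by tert-butyl in place of phenoxy on an aromatic carbon. Among the compounds with values here, with both known values at the limit there is no measured step to lean on; the expected step that the limit leaves unreadable from compound 2 to compound 3 in this assay is therefore small, and a true change in either direction would stay hidden if compound 3 also ends at the limit. Compound 3 is estimated at 2000 nM in this assay, with a range of 400 nM to 10000 nM, and a limit is again the most likely outcome.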

Compound 3, inhibition constant: 1000 nM
Compound 3: middle estimate off by 2.0-fold (0.30 log units), on the high side; the range from low to high includes it.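

Tert-butyl in place of phenoxy, on an aromatic carbon meta to a large group, gives the first reading in the series that is a number and not a limit: in this assay compound 3 gives 1000 nM. The change gives a number no higher from compound 2 to compound 3 (the limit leaves the size open), so this position accepts a group with no ring and no hydrogen-bond acceptor, and neither the aromatic ring of phenoxy nor its oxygen is required to reach that reading. The reading still stands at the very edge of what has been read in the series so far, and the other two compounds give only a limit: the limit of > 1000 nM in this assay, at which 2 of the 3 values shown sit.

On these data alone, whether the step from phenoxy to tert-butyl is a real gain stays open, as the reading for compound 3 falls on the same figure as the limit and that limit hides the true value of compound 2. Also open, as far as these compounds go, is how this position responds to groups of another kind, such as an amine, a carboxylic acid or a longer chain, and whether any of them gives a reading well under that of compound 3.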